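The compounds below may be only part of what the source reports. "The series", "measured", "known", "first", "only" and "open" are said of these compounds alone.

Compound 1 `CC(=O)N1CCc2nc(C)c(C(OC(C)(C)C)C(=O)O)c(-c3ccc(C)cc3)c2C1`: in an ADME assay on MT2 cells (Homo sapiens) for cytotoxicity, read by XTT assay, with a stated time of 4 days (on this read-out higher numbers stand for lower toxicity in this test and lower numbers for higher toxicity in this test), compound 1 gives > 40000 nM, a limit of the assay.
Compound 2 `Cc1nc2c(c(-c3cc(F)c4c(c3C)CCCO4)c1[C@H](OC(C)(C)C)C(=O)O)CN(CC1CC1c1ccccc1)CC2`: compound 2 gives > 40000 nM, likewise a limit of the assay.
Compound 3 `Cc1ccc(-c2c3c(nc(C)c2C(OC(C)(C)C)C(=O)O)CCN(CCCC2CCCC2)C3)cc1`: compound 3 gives > 40000 nM, again a limit of the assay.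

Compound 2 therefore stands at the limit of > 40000 nM in this assay, at which 3 of the 3 values shown sit; no number separates it from the other two compounds. Compound 4 `Cc1ccc(CCCN2CCc3nc(C)c([C@H](OC(C)(C)C)C(=O)O)c(-c4cc(F)c5c(c4C)CCCO5)c3C2)cc1` differs from compound 2 by 2-(4-methylphenyl)ethyl in place of 2-phenylcyclopropyl on a saturated chain carbon bound to an amine nitrogen in a ring. Among the measured compounds shown here, the one step with both ends measured, a step that the two limits leave unreadable from compound 1 to compound 3, runs between two limits, so its size cannot be read, and no measured step touches the change from compound 2 to compound 4. Nothing recorded points to a move away from the limit, so the expected step of a number no higher from compound 2 to compound 4 (the limit leaves the size open) is none beyond the scatter. Compound 4 is estimated at 40000 nM, between 20000 nM and 80000 nM.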

Compound 4, half-maximal cytotoxic concentration: > 40000 nM
Compound 4 gave a limit, no number; the forecaster's own chance of this, stated with the estimate: 85%; the middle value sits exactly at the limit.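

Compound 2 and compound 4 both give only a limit in this assay, and the step between them cannot be read. The compounds shown leave open the concentration at which any of them becomes cytotoxic in this assay: the limit of > 40000 nM in this assay, at which 4 of the 4 values shown sit.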